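Heteroaryl exchange on the amide-type nitrogen of compound 1

A few compounds are considered here, and "the series" means these few. Any claim that something is new, unique, unknown or untested is made for them only; others in the source may bear on it.

Compound 1 `Cc1ccc(OCC(=O)N(Cc2cccs2)c2ncco2)cc1` is the reference point of this set. In an assay on HEK293 cells for agonist activity at transient receptor potential cation channel subfamily M member 8 (Homo sapiens), read by fluorescence and calcium flux, with a stated time of 15 min (a higher number here means that more compound is needed for the effect, a lower number that less compound is needed), compound 1 gives 0.3 nM, the lowest of the two numbers in hand; compound 3 `CCN(Cc1ccc(C)s1)C(=O)COc1ccc(C)cc1` gives 178 nM, and the gap between the two lies beyond the scatter. Compound 2 `CCN1C(=O)C(Oc2ccc(C)cc2)C1c1cccs1` is reported as "active" (no number reported) without a number. Compound 4 `Cc1ccc(OCC(=O)N(Cc2cccs2)c2c[nH]nc2C)cc1` differs from compound 1 in a single place: 3-methyl-1H-pyrazol-4-yl in place of 1,3-oxazol-2-yl on an amide-type nitrogen. Among the measured compounds shown here, no step between measured compounds covers this exchange. The group on the amide-type nitrogen evidently matters, since compound 3 gives 178 nM, so a modest move toward a higher number is expected rather than none. Compound 4 is expected to give 5 nM, in the range 0.5 nM to 50 nM, a step of a 17-fold higher number from compound 1 to compound 4 (1.22 log units; beyond the scatter) estimated beyond the scatter.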

Compound 4, half-maximal effective concentration: 0.4 nM
The estimate for compound 4 lay 13-fold (1.10 log units) above the measured number, and the stated range ends above it.
By their numbers in this assay, from the lowest: compounds 1 and 4 (each within the scatter of the next); then compound 3.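

In this assay the exchange of 1,3-oxazol-2-yl for 3-methyl-1H-pyrazol-4-yl on the amide-type nitrogen gives a 1.3-fold higher number from compound 1 to compound 4 (0.12 log units; within the scatter) and so shows that this position takes either five-membered aromatic ring with 2 hetero atoms at a comparable number. The pair also shows that the added hydrogen-bond donor and the loss of one acceptor leave the two numbers within the scatter of each other. No measurement in hand explains this result. Still open, from the compounds shown here alone, is whether a phenyl or pyridin-2-yl group on this nitrogen would keep a number in the same range.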